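The source may report more compounds than this note shows. Statements on the series, on what has been measured and on what is new or still open speak of the compounds shown alone.

Three measured compounds share a core that carries a hexafluoro-substituted carbinol beside a phenol. Compound 1 `Oc1ccc(-c2ccccc2)cc1C(O)(C(F)(F)F)C(F)(F)F` and compound 3 `Oc1c(-c2ccccc2)cccc1C(O)(C(F)(F)F)C(F)(F)F` carry a plain phenyl ring on that core, while compound 2 `COc1ccc(CNC(=O)COc2ccc3cc(C(O)(C(F)(F)F)C(F)(F)F)c(O)cc3c2)cc1OC` extends it through an ether-linked amide. In an assay on isolated protein for inhibition of receptor-type tyrosine-protein phosphatase C (Homo sapiens), read by spectrophotometry (a higher number here means a weaker inhibitor, a lower number a stronger inhibitor), compound 3 gives 157000 nM. Compound 1 gives > 500000 nM in this assay, which is a limit of the assay and not a number. For compound 2 this assay records only > 20000 nM, again a limit rather than a number. So compound 2 stands among the values for which no number is known: the limit of > 20000 nM in this assay, at which 1 of the 3 values shown sits, and alongside it (the limit of > 500000 nM in this assay, at which 1 of the 3 values shown sits).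

Compound 4 `Cc1ccc(S(=O)(=O)NNC(=O)COc2ccc3cc(C(O)(C(F)(F)F)C(F)(F)F)c(O)cc3c2)cc1` is not yet measured. It differs from compound 2 in one place: ((4-methylphenyl)sulfonyl)amino in place of 3,4-dimethoxybenzyl on an amide-type nitrogen. Among the measured compounds shown here, no measured pair shows this kind of exchange, so there is no basis for expecting a step beyond the usual scatter in either direction. The step from compound 2 to compound 4 is therefore estimated as a step that the limit leaves unreadable from compound 2 to compound 4, and compound 4 is expected to give about 30000 nM, between 8000 nM and 150000 nM, with a real chance that only a limit is reported.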

Compound 4, half-maximal inhibitory concentration: 16100 nM
The estimate for compound 4 lay 1.9-fold (0.27 log units) above the measured number; the measured number falls inside the stated range.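

The exchange on the amide-type nitrogen gives the compounds with this longer side chain their first actual number: in this assay, compound 4 gives 16100 nM. Read as a change, this is an at least 1.2-fold lower number from compound 2 to compound 4 (0.09 log units; that floor lies within the scatter), so the printed floor by itself does not establish a real gain. The true size of the step stays unknown because compound 2 has only a limit: the limit of > 20000 nM in this assay, at which 1 of the 4 values shown sits.

Still open, on these data alone, is whether a smaller group on the same nitrogen, such as a carboxylic acid chain or a simple amine, would give a number in the same range. Compound 3 differs from compound 4 in more than one place, so what the whole side chain contributes to the shared core also remains unresolved.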